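Dichlorophenyl replaces dimethylphenyl on the triazole nitrogen

The source may report more compounds than this note shows. Statements on the series, on what has been measured and on what is new or still open speak of the compounds shown alone.

Compound 3 `Cc1ccc(C)c(-n2nncc2CN2C(=O)C3(C(C#N)=C(N)Oc4c3c3nc5ccccc5nc3c3ccccc43)c3ccccc32)c1` stands only at a limit in an ADME assay on L02 cells (Homo sapiens) for antiproliferative activity, read by MTT assay, with a stated time of 48 h (on this read-out higher numbers stand for weaker inhibition and lower numbers for stronger inhibition), giving > 50000 nM. Compound 2 `N#CC1=C(N)Oc2c(c3nc4ccccc4nc3c3ccccc23)C12C(=O)N(Cc1cnnn1-c1ccc([N+](=O)[O-])cc1)c1ccccc12` likewise sits at a limit, with > 50000 nM. Among the measured compounds shown here, compound 1 `N#CC1=C(N)Oc2c(c3nc4ccccc4nc3c3ccccc23)C12C(=O)N(Cc1cnnn1-c1cccc(Cl)c1)c1ccccc12` is the single compound with a number, giving 35200 nM. The change followed here, (3,4-dichlorophenyl in place of 2,5-dimethylphenyl on an aromatic nitrogen), yields compound 4 `N#CC1=C(N)Oc2c(c3nc4ccccc4nc3c3ccccc23)C12C(=O)N(Cc1cnnn1-c1ccc(Cl)c(Cl)c1)c1ccccc12`. For the measured compounds named here, two measured steps bear on it: an at least 1.4-fold higher number from compound 1 to compound 3 (0.15 log units; that floor lies within the scatter) and a step that the two limits leave unreadable from compound 2 to compound 3, and the limit of > 50000 nM in this assay, at which 2 of the 3 values shown sit, keeps both from saying more. With an at least 1.4-fold higher number from compound 1 to compound 3 (0.15 log units; that floor lies within the scatter) as the nearest guide, compound 4 is expected to remain near the limit, so the expected step is a number no higher from compound 3 to compound 4 (the limit leaves the size open), nothing beyond the scatter. Compound 4 is therefore estimated at 50000 nM, in a range from 20000 nM to 150000 nM.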

Compound 4, half-maximal inhibitory concentration: > 50000 nM
Compound 4 was reported as a limit (the forecaster's own chance of this, stated with the estimate: 60%); the middle value sits exactly at the limit.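

In this assay compound 4 gives > 50000 nM, which is a limit and not a number. Chloro in place of hydrogen on an aromatic carbon gives an at least 1.4-fold higher number from compound 1 to compound 4 (0.15 log units; that floor lies within the scatter), so the 3,4-dichlorophenyl group joins 4-nitrophenyl and 2,5-dimethylphenyl at the limit, and compound 1 alone keeps a number. The steps to compound 4 from compound 2 and compound 3 cannot be read, because each joins two limits: the limit of > 50000 nM in this assay, at which 3 of the 4 values shown sit.

As far as these compounds go, how far above the limit these compounds lie stays open. So does whether a phenyl group carrying an amine or a carboxylic acid at this position would give a number.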